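Working notes: lung metabolic stability across three amine variants

The source may report more compounds than this note shows. Statements on the series, on what has been measured and on what is new or still open speak of the compounds shown alone.

compound 1 `Cc1csc2cc([C@H](C)Nc3ncnc(N)c3C#N)c(-c3cccc(CN4CCC(CN(C)Cc5ccccn5)CC4)c3)c(=O)n12`: 5.2%
compound 2 `Cc1csc2cc([C@H](C)Nc3ncnc(N)c3C#N)c(-c3cccc(CN4CCC(N(C)CCC(F)(F)F)CC4)c3)c(=O)n12`: 3.5%
compound 3 `Cc1csc2cc([C@H](C)Nc3ncnc(N)c3C#N)c(-c3cccc(CN4CCC(N(C)C)CC4)c3)c(=O)n12`: 4.8%

In an ADME assay on the whole organism (lung, Rattus norvegicus) for metabolic stability, read by LC-MS, with a stated time of 24 h (a lower number here means that less of the compound is left, a higher number that more of the compound is left), compound 3 gives 4.8%, the second highest of the three numbers; compound 1 is nearest, compound 2 furthest, and both gaps lie within the scatter. Compound 4 `Cc1csc2cc([C@H](C)Nc3ncnc(N)c3C#N)c(-c3cccc(CN4CCC(CN(C)CC(C)C)CC4)c3)c(=O)n12` carries (isobutyl(methyl)amino)methyl in place of dimethylamino on a saturated ring carbon. Within the data shown here, the steps that bear on this change are a number 0.4 percentage points lower from compound 1 to compound 3 (within the scatter) and a number 1.3 percentage points higher from compound 2 to compound 3 (within the scatter), together with a number 1.7 percentage points lower from compound 1 to compound 2 (within the scatter); all three exchanges at the same ring carbon left the remaining fraction unmoved beyond the scatter. No step beyond the scatter is therefore expected in this assay for the change to compound 4. Compound 4 is expected to give 4.5%, between 1% and 10%. The expected step is a number 0.3 percentage points lower from compound 3 to compound 4 (within the scatter), which is estimated to fall within the scatter.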

Compound 4, percent of the compound remaining in the lung assay: 3.3%
Compound 4: the middle estimate sits 1.2 percentage points above what was measured; the measured number falls inside the stated range.
By their numbers in the lung assay, from the lowest: compounds 4, 2, 3 and 1 (each within the scatter of the next).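

In the lung assay the new amine stays level with all three earlier compounds: a number 1.5 percentage points lower from compound 3 to compound 4 (within the scatter), a number 0.2 percentage points lower from compound 2 to compound 4 (within the scatter) and a number 1.9 percentage points lower from compound 1 to compound 4 (within the scatter). In a physicochemical assay for acid dissociation, compound 3 gives 6.5 and compound 4 gives 8, which is a number 1.50 log units higher from compound 3 to compound 4 (beyond the scatter). Among these compounds, this exchange on the saturated ring carbon therefore moves the physicochemical assay clearly while the lung assay holds, a separation the earlier comparisons, all confined to the lung assay, could not show.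

On these data alone, whether (dimethylamino)methyl or a carboxylic acid on this ring carbon would shift either read-out remains open.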